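Swapping the Methoxy Group on the Shared Core

The compounds below may be only part of what the source reports. "The series", "measured", "known", "first", "only" and "open" are said of these compounds alone.

Among the measured compounds shown here, compound 1 `COc1ccc(-c2cncnc2-c2cc(OC)c(OC)c(OC)c2)cc1` stands at the higher of the two numbers so far in a functional assay on SiHa cells (Homo sapiens) for antiproliferative activity, read by CCK-8 assay, with a stated time of 72 h (a higher number here means a weaker inhibitor, a lower number a stronger inhibitor), where compound 1 gives 2850 nM. For the measured compounds named here, its only neighbour is compound 2 `CCSc1ccc(-c2cncnc2-c2cc(OC)c(OC)c(OC)c2)cc1`, which in this assay gives 1030 nM; the step is a 2.8-fold lower number from compound 1 to compound 2 (0.44 log units; beyond the scatter), with ethylsulfanyl in place of methoxy on an aromatic carbon.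

Compound 3 `COc1cc(-c2ncncc2-c2ccc(B(O)O)cc2)cc(OC)c1OC` differs from compound 1 in one place: a group of 3 heavy atoms (1 boron, 2 oxygen; no ring) in place of a group of 2 heavy atoms (1 carbon, 1 oxygen; no ring), on an aromatic carbon The entering group sits on an aromatic carbon of a six-membered aromatic ring of carbon only, para to a large group.

Going by the values given here, no measured step exchanges methoxy for this boron-bearing group. Among the compounds with values here, the one step at the same spot, from compound 1 to compound 2, was modest, so a change at this position can shift the number but has not done so strongly. Compound 3 is therefore expected to stay near compound 1, with a wide range and a slight lean toward a higher number. The expected step is a 1.4-fold higher number from compound 1 to compound 3 (0.15 log units; within the scatter). Compound 3 is estimated at 4000 nM, between 1000 nM and 16000 nM.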

Compound 3, half-maximal inhibitory concentration: 17500 nM
For compound 3 the middle estimate is 4.4-fold (0.64 log units) below the measured one; the whole stated range lies below it.
By their numbers in this assay, from the lowest: compound 2; then compound 1; then compound 3.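

The position on the aromatic carbon, para to a large group, now moves the number in both directions in this assay: the boron-bearing group in place of methoxy brings a 6.1-fold higher number from compound 1 to compound 3 (0.79 log units; beyond the scatter) and so runs opposite to the earlier ethylsulfanyl step. Set against ethylsulfanyl directly, the same group brings a 17-fold higher number from compound 2 to compound 3 (1.23 log units; beyond the scatter) and makes this the only large step so far, so this one position spans a wider range than the first pair showed. No measurement at hand accounts for this loss of activity.

The compounds shown leave open whether the loss belongs to boron itself or would also appear with other groups that carry hydrogen-bond donors, such as a carboxylic acid or an amine. They also leave open whether a longer sulfur-bearing chain than ethylsulfanyl would lower the number further.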